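Dropping the ethoxy group: compound 2 to compound 3

A few compounds are considered here, and "the series" means these few. Any claim that something is new, unique, unknown or untested is made for them only; others in the source may bear on it.

Compound 1 `COc1cc(/C=N/NC(=O)c2ccc(OCc3cc(OC)c(OC)c(OC)c3)cc2)cc(OC)c1O`: 75 ug/mL
Compound 2 `CCOc1cc(/C=N/NC(=O)c2ccc(OCc3cc(OC)c(OC)c(OC)c3)cc2)ccc1O`: 106 ug/mL

In a physicochemical assay, with a stated time of 30 min (on this read-out higher numbers stand for weaker inhibition and lower numbers for stronger inhibition), compound 2 gives the higher of the two numbers, but the step of a 1.4-fold higher number from compound 1 to compound 2 (0.15 log units; within the scatter) keeps it within the scatter of compound 1. Compound 3 `COc1cc(COc2ccc(C(=O)N/N=C/c3ccc(O)cc3)cc2)cc(OC)c1OC` carries the change (hydrogen in place of ethoxy on an aromatic carbon), read one bond further out as 3-ethoxy-4-hydroxyphenyl to 4-hydroxyphenyl. Among the compounds with values here, the single measured step, a 1.4-fold higher number from compound 1 to compound 2 (0.15 log units; within the scatter), also altered this ring and stayed within the scatter, so no step beyond the scatter is expected here, a 1.2-fold higher number from compound 2 to compound 3 (0.09 log units; within the scatter). Compound 3 is therefore estimated at 130 ug/mL, with a range from 60 ug/mL to 280 ug/mL.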

Compound 3, half-maximal inhibitory concentration: > 100 ug/mL
Compound 3 was reported as a limit (the forecaster's own chance of this, stated with the estimate: 5%); the middle value is on the limit's open side.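

In this assay compound 3 is reported only as a limit, so this position yields no number once the ethoxy group is gone: the limit of > 100 ug/mL in this assay, at which 1 of the 3 values shown sits. The step from compound 2 therefore cannot be read, and losing the ethoxy group has no measurable size here. From the compounds shown here alone, the comparison with the other alkoxy-bearing ring gives only a floor, an at least 1.3-fold higher number from compound 1 to compound 3 (0.12 log units; that floor lies within the scatter), so the true gap remains unknown.

Going by these compounds, what compound 3 would read beyond its limit stays open, as does whether an amine or a carboxylic acid on this aromatic carbon would shift the number.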